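A few compounds are considered here, and "the series" means these few. Any claim that something is new, unique, unknown or untested is made for them only; others in the source may bear on it.

Compound 1 `FC(F)(F)c1ccccc1-c1nc(NCc2ccc(-c3ccc(Cl)cc3)cc2)c2ccccc2n1`: 3600 nM in an assay on a protein complex for inhibition of ubiquitin carboxyl-terminal hydrolase 1/WD repeat-containing protein 48 (Homo sapiens), read by fluorescence; on this read-out higher numbers stand for weaker inhibition and lower numbers for stronger inhibition. Compound 2 `FC(F)(F)c1ccccc1-c1nc(NCc2ccc(-c3ccncc3)cc2)c2ccccc2n1`: 1900 nM.

In this assay compound 2 and compound 1 sit within the scatter of each other, so neither can be ranked above the other. Compound 3 `FC(F)(F)c1cc(-c2ccc(CNc3nc(-c4ccccc4C(F)(F)F)nc4ccccc34)cc2)ccn1` differs from compound 2 by trifluoromethyl in place of hydrogen on an aromatic carbon, on an aromatic carbon of a six-membered aromatic ring with 1 nitrogen, next to the ring nitrogen. Within the data shown here, no measured step matches this change; the only step known, a 1.9-fold lower number from compound 1 to compound 2 (0.28 log units; within the scatter), exchanged a whole ring and stayed within the scatter. The expected step is therefore no change at the digits printed from compound 2 to compound 3 (within the scatter), none beyond the scatter. Compound 3 is estimated at 1900 nM, between 700 nM and 5000 nM.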

Compound 3, half-maximal inhibitory concentration: 4900 nM
Compound 3: middle estimate off by 2.6-fold (0.41 log units), on the low side; measured number inside the range.
By their numbers in this assay, from the lowest: compounds 2, 1 and 3 (each within the scatter of the next, the first and the last beyond it).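

In this assay, putting trifluoromethyl in place of hydrogen next to the ring nitrogen gives a 2.6-fold higher number from compound 2 to compound 3 (0.41 log units; beyond the scatter), so this small addition carries a modest cost, which the earlier ring exchange did not show. Set against 4-chlorophenyl, 2-(trifluoromethyl)pyridin-4-yl gives only a 1.4-fold higher number from compound 1 to compound 3 (0.13 log units; within the scatter), so those two groups cannot be ranked. Nothing available explains the modest cost. Still open, as far as these compounds go, is how a methyl group, a methoxy group or an amine would behave at this same position.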